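The source may report more compounds than this note shows. Statements on the series, on what has been measured and on what is new or still open speak of the compounds shown alone.

Of the compounds shown here, three built on one shared core have been measured in a functional assay on MCF-10A cells (Homo sapiens) for antiproliferative activity, with a stated time of 48 h; a higher number here means that more compound is needed for the effect, a lower number that less compound is needed. In this assay, compound 1 (`COc1ccc2nc(C)cc(NCc3ccccc3OC)c2c1`) gives 29500 nM, compound 2 (`CCCOc1ccc2nc(C)cc(NCc3ccc(F)cc3)c2c1`) gives 14300 nM and compound 3 (`CCCCCCOc1ccc2nc(C)cc(NCc3ccc(F)cc3)c2c1`) gives 9100 nM. Compound 2 and compound 3 sit together at the low end of these numbers, within the scatter of each other, while the number for compound 1 stands higher than that of compound 3 by a gap beyond the scatter.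

The next compound is compound 4 (`Cc1cc(NCc2ccc(F)cc2)c2cc(OCCCCCCO)ccc2n1`), which differs from compound 3 in one place: hydroxy in place of hydrogen on a saturated chain carbon, six bonds along the chain from an oxygen on an aromatic ring. Within the data shown here, only one measured step bears on this chain, the entry of propyl in place of hydrogen on a saturated chain carbon, and it is a 1.6-fold lower number from compound 2 to compound 3 (0.20 log units; within the scatter). Among the measured compounds shown here, no measured compound carries a hydroxy, so the data give no direct guide to this change and only a weak hint on its direction. A shift beyond the scatter is therefore not expected in this assay, although the uncertainty is wide. The estimated change is a 1.2-fold higher number from compound 3 to compound 4 (0.08 log units; within the scatter). Compound 4 is expected at 11000 nM, with an estimated range from 4500 nM to 27000 nM.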

Compound 4, half-maximal effective concentration: 11300 nM
Estimate against measurement, compound 4: 1.0-fold (0.01 log units) below, within the range that was stated.
By their numbers in this assay, from the lowest: compounds 3, 4 and 2 (each within the scatter of the next); then compound 1.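

In this assay, the first hydroxy on this chain, on a saturated chain carbon six bonds along the chain from an oxygen on an aromatic ring, gives a 1.2-fold higher number from compound 3 to compound 4 (0.09 log units; within the scatter), so a group counted as one hydrogen-bond donor and one hydrogen-bond acceptor enters here without a shift beyond the scatter. The comparison with the shorter chain points the same way: 3-hydroxypropyl in place of hydrogen on a saturated chain carbon, three bonds along the chain from the same oxygen, gives a 1.3-fold lower number from compound 2 to compound 4 (0.10 log units; within the scatter), so neither change to this chain has yet moved the number beyond the scatter. Nothing available accounts for this result in terms of a measured property or mechanism.

Going by these compounds, whether an amine or a carboxylic acid in place of the hydroxy, or a longer chain, would produce a shift beyond the scatter remains open. Compound 1 differs from the other compounds in more than one place, and its number of 29500 nM cannot be tied to any single change.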